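The compounds below may be only part of what the source reports. "The series", "measured", "known", "first", "only" and "open" are said of these compounds alone.

Compound 1 `CCc1ccc(-c2nc3c(c(C)nn3-c3ccccc3)c(-c3ccccc3[N+](=O)[O-])c2C#N)cc1`: 1200 nM
Compound 2 `CCc1ccc(-c2nc3c(c(C)nn3-c3ccccc3)c(-c3ccccc3C)c2C#N)cc1`: 6000 nM

Both values come from a physicochemical assay for solubility, read by spectrophotometry, in phosphate buffer, with a stated time of 18 h, at pH 7.4; on this read-out higher numbers stand for higher solubility and lower numbers for lower solubility. Compound 2 has the higher of the two numbers. Compound 3 `CCc1ccc(-c2nc3c(c(C)nn3-c3ccccc3)c(-c3ccccc3OC)c2C#N)cc1` differs from compound 2 in one place, with methoxy in place of methyl on an aromatic carbon, ortho to a large group (methoxy in place of methyl on an aromatic carbon). Going by the values given here, only one measured step bears on this change. That step, a 5.0-fold higher number from compound 1 to compound 2 (0.70 log units; beyond the scatter), is modest but beyond the scatter, and it came from putting methyl in place of nitro. It involves the methyl group of compound 2 but no methoxy, so it gives only a rough sense of scale and no direction for the new change. No step beyond the scatter is therefore expected in this assay. The estimated change is a 1.2-fold lower number from compound 2 to compound 3 (0.08 log units; within the scatter). For compound 3 the expected value is 5000 nM, with an estimated range of 2000 nM to 12000 nM.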

Compound 3, solubility: 7800 nM
Compound 3: the middle estimate sits 1.6-fold (0.19 log units) below what was measured; the measured number falls inside the stated range.
By their numbers in this assay, from the lowest: compound 1; then compounds 2 and 3 (each within the scatter of the next).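

In this assay the change from 2-methylphenyl to 2-methoxyphenyl, on an aromatic carbon ortho to a large group, gives a 1.3-fold higher number from compound 2 to compound 3 (0.11 log units; within the scatter), so methyl and methoxy cannot be told apart at this place. Set against nitro, methoxy gives a 6.5-fold higher number from compound 1 to compound 3 (0.81 log units; beyond the scatter), a step beyond the scatter like a 5.0-fold higher number from compound 1 to compound 2 (0.70 log units; beyond the scatter), which leaves compound 1 as the only one of the three compounds set apart from the others by its number. Nothing shown gives a measured reason for these numbers.

On these data alone, it remains open whether an amine, a carboxylic acid or a longer chain such as ethoxy at this place would stay with compound 2 and compound 3 or move away from them. As far as these compounds go, it is also open whether the match between methyl and methoxy would hold on a different core.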